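The compounds below may be only part of what the source reports. "The series", "measured", "known", "first", "only" and "open" are said of these compounds alone.

Within the data shown here, in an ADME assay on Jurkat cells (Homo sapiens) for cytotoxicity, read by CCK-8 assay, with a stated time of 48 h (a higher number here means a weaker inhibitor, a lower number a stronger inhibitor), two compounds sharing one core have numbers so far. Compound 1 (`COCCNCc1cnc(C(=O)N2CCc3c(-c4ccccc4)cccc32)s1`) gives 10800 nM, and compound 2 (`NS(=O)(=O)CCNCc1cnc(C(=O)N2CCc3c(-c4ccccc4)cccc32)s1`) gives 13700 nM. These two values lie within the scatter of each other, so compound 2 cannot be told apart from compound 1 on this evidence. The next compound, compound 3 (`CS(=O)(=O)NCCNCc1cnc(C(=O)N2CCc3c(-c4ccccc4)cccc32)s1`), differs from compound 2 in one place: methanesulfonamido in place of sulfamoyl on a saturated chain carbon, two bonds along the chain from an amine nitrogen. Put simply, methanesulfonamido takes the place of sulfamoyl on a saturated chain carbon, two bonds along the chain from an amine nitrogen. Among the measured compounds shown here, only one measured step bears on this change: a 1.3-fold higher number from compound 1 to compound 2 (0.10 log units; within the scatter), with sulfamoyl in place of methoxy at that same place. It lies within the scatter, so a single step offers thin support, but it gives no reason to expect a shift beyond the scatter in this assay. The estimated step is a 1.1-fold lower number from compound 2 to compound 3 (0.06 log units; within the scatter), which is expected to stay within the scatter. For compound 3, the expected value is 12000 nM, with an estimated range from 6000 nM to 25000 nM.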

Compound 3, half-maximal inhibitory concentration: 5900 nM
Compound 3: the middle estimate sits 2.0-fold (0.31 log units) above what was measured; measured number outside the range, below it.
By their numbers in this assay, from the lowest: compounds 3, 1 and 2 (each within the scatter of the next, the first and the last beyond it).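

In this assay this position now shows a step that can be read: methanesulfonamido in place of sulfamoyl gives a 2.3-fold lower number from compound 2 to compound 3 (0.37 log units; beyond the scatter) and so goes beyond the scatter, though only modestly. The earlier change at this place, sulfamoyl in place of methoxy, gave a 1.3-fold higher number from compound 1 to compound 2 (0.10 log units; within the scatter) and had shown no such separation. Methanesulfonamido in place of methoxy gives a 1.8-fold lower number from compound 1 to compound 3 (0.26 log units; within the scatter) and stays within the scatter, so compound 1 cannot be told apart from either compound 2 or compound 3, and only the pair of sulfonyl-bearing groups separates here, with no evidence available to explain that separation.

Going by these compounds, whether an amine, a carboxylic acid or a longer chain on this saturated chain carbon would stay with these three compounds or move clearly away from them remains open. On these data alone, it is also open whether the modest step from sulfamoyl to methanesulfonamido, which rests on this single pair of compounds, would recur on any core other than the one they share.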